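A few compounds are considered here, and "the series" means these few. Any claim that something is new, unique, unknown or untested is made for them only; others in the source may bear on it.

Compound 1 `CC1=C(C(=O)Nc2ccc(Br)cc2)C(c2ccc(Cl)cc2Cl)N=C(SCc2ccccc2)N1` and compound 2 `CC1=C(C(=O)Nc2ccc(Br)cc2)C(c2ccc(Cl)cc2Cl)N=C(SCc2cccc(Cl)c2)N1` share one core and were both tested in a functional assay on the whole organism (artery, strain albino) with Rattus norvegicus as the target, with a stated time of 120 min, at a dose of 10 mg/kg by the oral route; a lower number here means less inhibition, a higher number more inhibition at the dose given (going by the name of the read-out). In this assay compound 1 gives 10.3%, and compound 2 gives 8.8%. The structural difference between them is chloro in place of hydrogen on an aromatic carbon, and that change made a step of a number 1.5 percentage points lower from compound 1 to compound 2 (within the scatter). Compound 3 `CC1=C(C(=O)Nc2ccc([N+](=O)[O-])cc2)C(c2ccc(Br)cc2)N=C(SCc2ccccc2)N1` differs from compound 1 in more than one place, so the difference between the two cores is not broken down here. In this assay compound 3 gives 13.4%, which lies within the scatter of both compound 1 and compound 2. Compound 4 `CC1=C(C(=O)Nc2ccc([N+](=O)[O-])cc2)C(c2ccc(Br)cc2)N=C(SCc2ccccc2Cl)N1` has not yet been measured. It differs from compound 3 by chloro in place of hydrogen on an aromatic carbon. For the measured compounds named here, this is the same kind of change as the one from compound 1 to compound 2, but not the same: in compound 2 the chloro sits meta to a large group, whereas in compound 4 it sits ortho to a large group. Since the earlier step was a number 1.5 percentage points lower from compound 1 to compound 2 (within the scatter), the step of a number 1.4 percentage points lower from compound 3 to compound 4 (within the scatter) is expected to stay small as well. Compound 4 is therefore estimated at 12%, with a likely range from 3% to 22%.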

Compound 4, a percentage reported as inhibition, in the whole organism at one dose (the size of the read-out at that dose, not a potency): 7.7%
For compound 4 the middle estimate is 4.3 percentage points above the measured one; the range from low to high includes it.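

In this assay, placing a chloro on the benzyl group of compound 3 gave a number 5.7 percentage points lower from compound 3 to compound 4 (within the scatter). Set beside the earlier case, the two steps agree as closely as repeated measurements would be expected to: the same change on two cores in this assay, a number 1.5 percentage points lower (within the scatter) from compound 1 to compound 2 and a number 5.7 percentage points lower (within the scatter) from compound 3 to compound 4, 4.2 percentage points apart, within the scatter of two such steps. So on these two cores the change gives no step beyond the scatter, but this rests on only two pairs, the chloro does not stand at the same place on the benzyl group in both, and neither step shows that the chloro changes the read-out at all.

The compounds shown carry only hydrogen or chloro on this benzyl group, which leaves open what an amine or a carboxylic acid there would do, and whether a longer chain in place of the benzyl would move the number beyond the scatter. They also leave open whether 2-chlorobenzyl would give a similar step on the core of compound 1.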